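This account rests on a few compounds, and the source may have more. Where it says the series, first, only, none or still open, it means among the compounds named here.

Measured compounds:
compound 1 `CC(C)(CC(=O)N[C@@H]1CCc2ccccc2N(Cc2ccc(-c3ccccc3-c3nn[nH]n3)cc2)C1=O)NC[C@H](O)CO` — 10 nM
compound 2 `C[C@H](O)CNC(C)(C)C(=O)N[C@@H]1CCc2ccccc2N(Cc2ccc(-c3ccccc3-c3nn[nH]n3)cc2)C1=O` — 700 nM
compound 3 `C[C@@H](O)CCNC(C)(C)C(=O)N[C@@H]1CCc2ccccc2N(Cc2ccc(-c3ccccc3-c3nn[nH]n3)cc2)C1=O` — 100 nM

In a functional assay (Pituitary gland cell) with Rattus norvegicus as the target (a lower number here means that less compound is needed, a higher number that more compound is needed for the effect), compound 1 gives the lowest number of the three; the nearest is compound 3 at a 10-fold higher number from compound 1 to compound 3 (1.00 log units; beyond the scatter) and the furthest compound 2 at a 70-fold higher number from compound 1 to compound 2 (1.85 log units; beyond the scatter). Compound 4 `C[C@H](O)CCNC(C)(C)C(=O)N[C@@H]1CCc2ccccc2N(Cc2ccc(-c3ccccc3-c3nn[nH]n3)cc2)C1=O` differs from compound 1 by 1-((3-hydroxybutyl)amino)-1-methylethyl in place of 2-((2,3-dihydroxypropyl)amino)-2-methylpropyl on a carbonyl carbon. The same change in group name, with the other configuration at the hydroxybutyl stereocentre, was measured as a 10-fold higher number from compound 1 to compound 3 (1.00 log units; beyond the scatter). Among the compounds with values here, no pair in the set shows the effect of that stereocentre alone, so compound 3 is the only direct guide. For compound 4 a step of a 10-fold higher number from compound 1 to compound 4 (1.00 log units; beyond the scatter) is therefore expected, with a wider range to allow for the unmeasured configuration. The estimate for compound 4 in this assay is 100 nM, between 30 nM and 400 nM.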

Compound 4, concentration for half-maximal effect: 50 nM
Compound 4: middle estimate off by 2.0-fold (0.30 log units), on the high side; low and high end bracket the measured number.
By their numbers in this assay, from the lowest: compound 1; then compounds 4 and 3 (each within the scatter of the next); then compound 2.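

In this assay, within the data shown here, the hydroxybutyl stereocentre can now be read alone, and it separates the two epimers only by a 2.0-fold lower number from compound 3 to compound 4 (0.30 log units; within the scatter), the one pair isolating configuration: the fact that compounds 3 and 4 differ only in the configuration as drawn. With either configuration, the 2-hydroxypropyl in place of 1-hydroxyethyl change still counts, at a 14-fold lower number from compound 2 to compound 4 (1.15 log units; beyond the scatter). Compound 1 also keeps its lead, at a 5.0-fold higher number from compound 1 to compound 4 (0.70 log units; beyond the scatter).

Still open is which part of the 2-((2,3-dihydroxypropyl)amino)-2-methylpropyl group accounts for that lead, the second hydroxyl or the chain carrying the amine. On these data alone, how a carboxylic acid or a primary amine in place of the terminal hydroxyl would read in this assay also remains open.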